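Aryl thioether in place of aryl ether on the shared core

This account rests on a few compounds, and the source may have more. Where it says the series, first, only, none or still open, it means among the compounds named here.

compound 1 `Nc1cc(N)c2nc(-c3ccccc3)c(Oc3ccc(Cl)c(Cl)c3)nc2c1`: 67600 nM
compound 2 `COc1cc(CNc2nc3cc(N)cc(N)c3nc2-c2ccccc2)cc(OC)c1OC`: < 50200 nM (a limit)
compound 3 `COc1ccc(CNc2nc3cc(N)cc(N)c3nc2-c2ccccc2)cc1`: 33900 nM

In a functional assay on COLO 205 cells (Homo sapiens) for inhibition, read by sulforhodamine B assay, with a stated time of 48 h (on this read-out lower numbers stand for stronger inhibition of growth and higher numbers for weaker inhibition of growth), compound 1 gives 67600 nM, the highest of the two numbers. Compound 3 gives 33900 nM, within the scatter of compound 1. Compound 2 reaches only a limit, < 50200 nM (the limit of < 50200 nM in this assay, at which 1 of the 3 values shown sits). Compound 4 `COc1ccc(Sc2nc3cc(N)cc(N)c3nc2-c2ccccc2)cc1` differs from compound 1 by (4-methoxyphenyl)sulfanyl in place of 3,4-dichlorophenoxy on an aromatic carbon. For the measured compounds named here, no measured step between two compounds covers this change, so the expectation rests on the spread of the values seen. The step from compound 1 to compound 4 is expected to be a 1.5-fold lower number from compound 1 to compound 4 (0.18 log units; within the scatter), not beyond the scatter. Compound 4 is therefore estimated at 45000 nM, between 15000 nM and 120000 nM.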

Compound 4, concentration for total growth inhibition: < 100000 nM
Compound 4 ended at the assay's limit (the forecaster's own chance of this, stated with the estimate: 15%); the middle value does not contradict the limit.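

In this assay, for the compounds shown here, compound 4 gives < 100000 nM, a limit, so no step from compound 1 to compound 4 can be read. From the compounds shown here alone, whether (4-methoxyphenyl)sulfanyl in place of 3,4-dichlorophenoxy changes growth inhibition on the shared core stays open.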